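Adding a methyl to a compound at the limit

This account rests on a few compounds, and the source may have more. Where it says the series, first, only, none or still open, it means among the compounds named here.

Measured in a functional assay on the whole organism (Abdomen) with Mus musculus as the target; on this read-out higher numbers stand for an effect only at larger amounts of compound and lower numbers for an effect already at smaller amounts:
- Compound 1 `CCCCc1nc(Cc2c[nH]cn2)c(CCCC)s1`: > 30 mg/kg
- Compound 2 `CCc1nc(CC)c(Cc2c[nH]cn2)s1`: > 30 mg/kg

Compound 2 stands at > 30 mg/kg, which is a limit of the assay and not a number. So far the picture is the limit of > 30 mg/kg in this assay, at which 2 of the 2 values shown sit. Compound 3 `CCc1nc(CC)c(C(C)c2c[nH]cn2)s1` carries methyl in place of hydrogen on a saturated chain carbon bound to two aromatic carbons. Among the compounds with values here, no measured step shows what such a change does, so any forecast is loose. Expected here is an at least 1.5-fold lower number from compound 2 to compound 3 (0.17 log units; that floor lies within the scatter), a modest move toward smaller doses that may not exceed the scatter. For compound 3 the estimated dose is 20 mg/kg, with an expected range from 4 mg/kg to 60 mg/kg.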

Compound 3, dose for half-maximal effect: > 30 mg/kg
Compound 3: no number, only a limit; the forecaster's own chance of this, stated with the estimate: 50%; middle value at least 1.5-fold (0.17 log units) from the limit.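

Compound 2 and compound 3 each give only a limit and not a number, so the swap of hydrogen for methyl cannot be read: the limit of > 30 mg/kg in this assay, at which 3 of the 3 values shown sit.

The compounds shown leave open whether this methyl changes the dose needed, and at what dose any of them would act.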